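The source may report more compounds than this note shows. Statements on the series, on what has been measured and on what is new or still open speak of the compounds shown alone.

In an ADME assay on HEK-293T cells (Homo sapiens) for cytotoxicity, read by CCK-8 assay, with a stated time of 48 h (a lower number here means a stronger inhibitor, a higher number a weaker inhibitor), compound 3 `O=[N+]([O-])c1ccc(NC(=S)NCCNS(=O)(=O)c2ccc(-c3ccccc3OCc3ccccc3)s2)cc1` gives 8900 nM. Compound 2 `O=S(=O)(NCCNC(=S)Nc1cccc(Cl)c1)c1ccc(-c2ccccc2OCc2ccccc2)s1` gives 10200 nM, and these two numbers lie within the scatter of each other, so compound 3 cannot be separated from its nearest neighbour. Compound 1 `Cc1cc(C)cc(NC(=O)NCCNS(=O)(=O)c2ccc(-c3ccccc3Oc3ccc([N+](=O)[O-])c([N+](=O)[O-])c3)s2)c1` reads > 50000 nM, which is a limit of the assay and not a number.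

Compound 4 `Cc1cc(C)cc(NC(=O)NCCNS(=O)(=O)c2ccc(-c3ccccc3OCc3ccccc3)s2)c1` arises from compound 3 by a single exchange: a group of 11 heavy atoms (9 carbon, 1 nitrogen, 1 oxygen; one six-membered aromatic ring of carbon only) in place of a group of 12 heavy atoms (7 carbon, 2 nitrogen, 2 oxygen, 1 sulfur; one six-membered aromatic ring of carbon only), on an amine nitrogen. Within the data shown here, only one measured step bears on this, and only in part. It puts 4-nitrophenyl in place of 3-chlorophenyl on an amide-type nitrogen and gives a 1.1-fold lower number from compound 2 to compound 3 (0.06 log units; within the scatter). That step swaps the ring alone, whereas the present exchange also removes the sulfur of the group that leaves.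

Compound 1 also carries (3,5-dimethylphenyl)carbamoyl and reads > 50000 nM, a limit, and on this slender ground alone a modest move to a higher number is expected in this assay. The expected step is a 2.2-fold higher number from compound 3 to compound 4 (0.35 log units; beyond the scatter). For compound 4 the estimate is 20000 nM, with an expected range from 7000 nM to 50000 nM.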

Compound 4, half-maximal inhibitory concentration: > 20000 nM
Compound 4: a limit, no number (the forecaster's own chance of this, stated with the estimate: 25%); the middle value lies on the limit itself.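

Putting (3,5-dimethylphenyl)carbamoyl on the amine nitrogen gives an at least 2.2-fold higher number from compound 3 to compound 4 (0.35 log units; beyond the scatter) in this assay, so this position can respond to a change of group, whereas the earlier ring swap stayed within the scatter. The same kind of exchange gives an at least 1.9-fold higher number from compound 2 to compound 4 (0.29 log units; that floor lies within the scatter), and that floor alone does not separate the two compounds. Both sizes are only floors, because compound 4 reads as a limit and not a number: the limit of > 20000 nM in this assay, at which 1 of the 4 values shown sits.

The step between compound 1 and compound 4 cannot be read, with a limit on both sides. Also open, on these data alone, is whether the loss of the sulfur or the change of ring carries the step from compound 3 to compound 4, and how a ring bearing an amine or a carboxylic acid would read at this position.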